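The compounds below may be only part of what the source reports. "The series", "measured", "known", "first", "only" and "open" are said of these compounds alone.

Compound 1 `Cc1cccc2c1nc(-c1c(F)cccc1F)n2Cc1c(F)cccc1F` carries a methyl group on the shared core. In a toxicity assay on CCRF-CEM cells (Homo sapiens) for cytotoxicity (a higher number here means that more compound is tolerated, a lower number that less compound is tolerated), compound 1 gives only a limit, > 100 uM, so its number is not known. Compound 2 `N#Cc1cccc2c1nc(-c1c(F)cccc1F)n2Cc1c(F)cccc1F` gives 26.7 uM in this assay, and compound 3 `N=C(NO)c1cccc2c1nc(-c1c(F)cccc1F)n2Cc1c(F)cccc1F` gives 23.1 uM. Both steps away from compound 1 lowered the number: an at least 3.7-fold lower number from compound 1 to compound 2 (0.57 log units; beyond the scatter) and an at least 4.3-fold lower number from compound 1 to compound 3 (0.63 log units; beyond the scatter), while a 1.2-fold lower number from compound 2 to compound 3 (0.06 log units; within the scatter). Compound 4 `CC(C)c1cccc2c1nc(-c1c(F)cccc1F)n2Cc1c(F)cccc1F` differs from compound 1 by isopropyl in place of methyl on an aromatic carbon. Going by the values given here, none of the measured steps exchanges methyl for a larger carbon group; the two that start from compound 1 introduce cyano or the group of 4 heavy atoms. The step to compound 4 is therefore expected to stay within the scatter, a number no higher from compound 1 to compound 4 (the limit leaves the size open). Compound 4 is expected to give about 100 uM in this assay, between 50 uM and 200 uM.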

Compound 4, half-maximal toxic concentration: 27 uM
For compound 4 the middle estimate is 3.7-fold (0.57 log units) above the measured one, outside the stated range (below it).
By their numbers in this assay, from the lowest: compounds 3, 2 and 4 (each within the scatter of the next). At a limit, above all of these: compound 1.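

In this assay, the exchange of methyl for isopropyl alone is enough to move the number (an at least 3.7-fold lower number from compound 1 to compound 4 (0.56 log units; beyond the scatter)). The earlier steps shown here from compound 1 brought in groups holding nitrogen, whereas this one enters carbon only, with no hydrogen-bond donors or acceptors. Even so, the values stay level (a 1.0-fold higher number from compound 2 to compound 4 (0.00 log units; within the scatter); a 1.2-fold higher number from compound 3 to compound 4 (0.07 log units; within the scatter)).

From the compounds shown here alone, the true size of the step from compound 1 remains open: (the limit of > 100 uM in this assay, at which 1 of the 4 values shown sits). Also open, going by these compounds, is whether an amine, a carboxylic acid or a longer chain on this aromatic carbon would give a value level with these three.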